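Replacing diethylamino with nitro on compound 1

The source may hold more compounds than are shown below. What is called first, only, known or untested is meant among the compounds shown, and "the series" means these compounds.

Within the data shown here, in a functional assay on MT4 cells (Homo sapiens) for antiproliferative activity, read by MTT assay, with a stated time of 96 h (on this read-out lower numbers stand for stronger inhibition and higher numbers for weaker inhibition), compound 1 `CCN(CC)c1ccc(N2C(=O)NC3(CSC4=C3C(=O)c3ncccc3C4=O)C2=O)cc1` gives 8 nM, the lowest number of the three compounds measured so far. Compound 3 `O=C1NN(c2ccccc2)C(=O)C2(CSC3=C2C(=O)c2ncccc2C3=O)N1` gives 150 nM, and compound 2 `O=C1NNC(=O)C2(CSC3=C2C(=O)c2ncccc2C3=O)N1` gives 550 nM; 500 nM; 550 nM (3 entries). Compound 4 `O=C1C2=C(C(=O)c3ncccc31)C1(CS2)NC(=O)N(c2ccc([N+](=O)[O-])cc2)C1=O` has not yet been measured. It differs from compound 1 at one place, with nitro in place of diethylamino on an aromatic carbon, para to a large group: nitro in place of diethylamino on an aromatic carbon. Among the measured compounds shown here, no measured step isolates this change, so the expectation is loose. With compound 1 at 8 nM, a moderate move toward a higher number, meaning weaker inhibition, is expected in this assay. The expected step is a 5.0-fold higher number from compound 1 to compound 4 (0.70 log units; beyond the scatter). For compound 4, the estimated value is 40 nM, with an expected range of 10 nM to 200 nM.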

Compound 4, half-maximal inhibitory concentration: 8 nM
For compound 4 the middle estimate is 5.0-fold (0.70 log units) above the measured one; the whole stated range lies above it.
By their numbers in this assay, from the lowest: compounds 1 and 4 (each within the scatter of the next); then compound 3.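

In this assay, putting nitro in place of diethylamino on an aromatic carbon, para to a large group, gives no change at the digits printed from compound 1 to compound 4 (within the scatter). This single pair shows that the read-out at this place tolerates the exchange of an alkylated amine for nitro, though the two groups share little beyond their nitrogen. The read-out repeats closely in this assay, as seen in: the several entries of compound 2 in this assay, 550 nM; 500 nM; 550 nM (3 entries)

On these data alone, whether a plain amine, a methoxy group or a carboxylic acid at this place would hold the number remains open. So does the outcome with hydrogen there.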